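This account rests on a few compounds, and the source may have more. Where it says the series, first, only, none or still open, it means among the compounds named here.

Compound 1 `C[C@@H]1CN(C(=O)[C@@H]2C[C@H](S(=O)(=O)c3ccccc3)C[C@H]2C(=O)NC2(C#N)CC2)C[C@H](C)O1` is tested in a functional assay on A20 cells (Mus musculus) for inhibition, with stated times of 1 h, 16 h and 24 h (on this read-out lower numbers stand for stronger inhibition and higher numbers for weaker inhibition), and gives 1 nM. Among the three measured compounds this is the lowest number. The nearest neighbour is compound 3 `CC1CCN(C(=O)[C@@H]2C[C@H](S(=O)(=O)c3ccccc3)C[C@H]2C(=O)NC2(C#N)CC2)CC1`, which gives 2 nM; the step of a 2.0-fold higher number from compound 1 to compound 3 (0.30 log units; within the scatter) stays within the scatter, so the two cannot be told apart. The furthest is compound 2 `N#CC1(NC(=O)[C@@H]2C[C@@H](S(=O)(=O)c3ccccc3)C[C@H]2C(=O)N2CC3(COC3)C2)CC1`, which gives 248 nM; the step of a 250-fold higher number from compound 1 to compound 2 (2.39 log units; beyond the scatter) is large.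

Compound 4 `N#CC1(NC(=O)[C@@H]2C[C@@H](S(=O)(=O)c3ccccc3)C[C@H]2C(=O)N2CCCC2)CC1` has not yet been measured. It differs from compound 1 in one place: pyrrolidin-1-yl in place of 2,6-dimethylmorpholin-4-yl on a carbonyl carbon. Within the data shown here, two measured steps bear on this change. Swapping the 2,6-dimethylmorpholin-4-yl for 4-methylpiperidin-1-yl, another six-membered non-aromatic ring, moved the number only by a 2.0-fold higher number from compound 1 to compound 3 (0.30 log units; within the scatter), whereas swapping it for a group built from two four-membered non-aromatic rings produced the large loss of a 250-fold higher number from compound 1 to compound 2 (2.39 log units; beyond the scatter). Pyrrolidin-1-yl, one five-membered non-aromatic ring with 1 hetero atom, sits between these two cases and matches neither closely, so a moderate rise in the number is expected, beyond the scatter but far smaller than the loss seen in compound 2. For compound 4 the expected step is an 8.0-fold higher number from compound 1 to compound 4 (0.90 log units; beyond the scatter), giving an estimate of 8 nM, with a range from 2 nM to 50 nM.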

Compound 4, half-maximal inhibitory concentration: 29 nM
For compound 4 the middle estimate is 3.6-fold (0.56 log units) below the measured one; the measured number falls inside the stated range.
By their numbers in this assay, from the lowest: compounds 1 and 3 (each within the scatter of the next); then compound 4; then compound 2.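

In this assay, the change to pyrrolidin-1-yl on this carbonyl carbon proves far from neutral, with a 29-fold higher number from compound 1 to compound 4 (1.46 log units; beyond the scatter) and a 15-fold higher number from compound 3 to compound 4 (1.16 log units; beyond the scatter), both large steps, so this position tolerates some changes but not all, and the swap between the two six-membered rings gave no warning of this. Compound 4 still keeps part of the loss seen with the two four-membered rings, as an 8.6-fold lower number from compound 2 to compound 4 (0.93 log units; beyond the scatter) is a modest step in the other direction. Size alone does not order the series: the pyrrolidin-1-yl group of compound 4 has the fewest heavy atoms, yet compound 2 has the highest number, and its group matches the 4-methylpiperidin-1-yl group of compound 3 in heavy-atom count.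

Nothing available explains why these groups differ so much. As far as these compounds go, it remains open whether the low numbers of compound 1 and compound 3 depend on the six-membered ring itself or on its methyl groups, a question that plain piperidin-1-yl or morpholin-4-yl on the same carbonyl carbon could help to separate.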